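This account rests on a few compounds, and the source may have more. Where it says the series, first, only, none or still open, it means among the compounds named here.

Measured so far, in a functional assay, with a stated time of 150 min, tested at 25 ug/mL; on this read-out higher numbers stand for a stronger effect at the one concentration tested and lower numbers for a weaker effect:
compound 1, `COC(=O)c1c(Nc2ccc(F)cc2)sc(C(=O)c2ccc(OC)cc2)c1C`: 20.2%
compound 2, `COc1ccc(C(=O)c2sc(Nc3ccc(C)cc3)c(C(=O)O)c2C)cc1`: "not active" (no number reported)

Compound 2 stands at the bottom of what is known: in this assay compound 2 is reported as "not active" (no number reported), with no number attached, while compound 1 gives 20.2%. Among the compounds with values here, no step between two measured compounds is available for the change now considered, so the account rests on these two values alone.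

Compound 3, `COc1ccc(C(=O)c2sc(Nc3ccc(F)cc3)c(C(=O)O)c2C)cc1`, differs from compound 2 by fluoro in place of methyl on an aromatic carbon. Compound 1 carries the same fluoro group together with a methyl ester rather than the free acid, and its read-out in this assay is modest. The step from compound 2 to compound 3 in this assay is therefore expected to be small, upward if anything, and plausibly no larger than the usual scatter, with a fair chance that compound 3 is again reported without a number. Compound 3 is estimated at 8%, within a range from 0% to 22%.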

Compound 3, a percentage reported as activity, at one concentration (the size of the read-out at that concentration, not a potency): 0.836%
Compound 3: middle estimate off by 7.2 percentage points, on the high side, and the stated range covers the measured number.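

In this assay, within the data shown here, placing hydrogen rather than methyl on the oxygen next to the carbonyl group, with the 4-fluorophenyl group held constant, gives a number 19.4 percentage points lower from compound 1 to compound 3 (beyond the scatter), the first readable step. It shows that the methyl ester and free acid forms are distinguishable on this read-out when the rest of the structure is unchanged. The change from 4-methylphenyl to 4-fluorophenyl cannot be read as a step, since compound 2 has no number. No available measurement bears on why the ester-to-acid step occurs.

As far as these compounds go, whether an ethyl ester or a primary amide at that position would behave like the methyl ester remains open. So does whether chloro or methoxy on the same aromatic carbon would change the read-out for the acid or the ester.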